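From phenyl to thiophen-3-yl in compound 3

A few compounds are considered here, and "the series" means these few. Any claim that something is new, unique, unknown or untested is made for them only; others in the source may bear on it.

Measured so far in an ADME assay on LLC-MK2 cells (Macaca mulatta) for cytotoxicity, read by spectrophotometry and crystal violet staining, with a stated time of 4 days (a lower number here means that less compound is tolerated, a higher number that more compound is tolerated), as half-maximal cytotoxic concentration:

- Compound 1 `CC(C)n1ncc2c(C(=O)Nc3ncccn3)cc(-c3ccsc3)nc21` gives 50000 nM in this test
- Compound 2 `CC(C)n1ncc2c(C(=O)Nc3ccccn3)cc(-c3ccccc3)nc21` gives 12500 nM in this test

Compound 2 holds the lower of the two numbers, and compound 1 lies above it by more than the usual scatter. Compound 3 `CC(C)n1ncc2c(C(=O)Nc3ccccn3)cc(-c3ccsc3)nc21` has thiophen-3-yl in place of phenyl on an aromatic carbon of compound 2. For the measured compounds named here, no measured pair isolates this change. Compound 1, which also bears thiophen-3-yl, reads 50000 nM and so suggests a modest rise at most. The expected change is a 1.6-fold higher number from compound 2 to compound 3 (0.20 log units; within the scatter) in the upward direction. For compound 3 the estimated value in this assay is 20000 nM, with an expected range from 9000 nM to 50000 nM in this test.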

Compound 3, half-maximal cytotoxic concentration: 25000 nM
Estimate against measurement, compound 3: 1.3-fold (0.10 log units) below; the range from low to high includes it.
By their numbers in this assay, from the lowest: compounds 2, 3 and 1 (each within the scatter of the next, the first and the last beyond it).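

In this assay, thiophen-3-yl in place of phenyl on the aromatic carbon next to the ring nitrogen gives a 2.0-fold higher number from compound 2 to compound 3 (0.30 log units; within the scatter), so this change, now isolated in a single pair, stays inside the scatter. Pyridin-2-yl in place of pyrimidin-2-yl on the amide-type nitrogen gives a 2.0-fold lower number from compound 1 to compound 3 (0.30 log units; within the scatter), so the second single change also stays inside it. Nothing available bears on a cause for these readings. The compounds shown leave open how this assay reads with an amine or a carboxylic acid at the thiophen-3-yl position.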